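Removing one chloro from a dichlorophenyl thioglycoside

The source may hold more compounds than are shown below. What is called first, only, known or untested is meant among the compounds shown, and "the series" means these compounds.

Measured compounds in a functional assay on PBMC cells (Homo sapiens) for inhibition, read by thymidine incorporation, with a stated time of 72 h; a higher number here means a weaker inhibitor, a lower number a stronger inhibitor:
- compound 1 `CC(=O)OC[C@H]1O[C@@H](SC(=S)C2=C(Nc3ccc(Cl)cc3Cl)CC(C)(C)CC2=O)[C@H](OC(C)=O)[C@@H](OC(C)=O)[C@@H]1OC(C)=O` gives 15.8 ug/mL
- compound 2 `CC(=O)OC[C@H]1O[C@@H](SC(=S)C2=C(Nc3ccc(Cl)cc3Cl)CC(C)(C)CC2=O)[C@H](OC(C)=O)[C@@H](OC(C)=O)[C@H]1OC(C)=O` gives 3.9 ug/mL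

Compound 1 stands at the higher of the two numbers, so it is the weaker of the two inhibitors. Within the data shown here, the one measured step, a 4.1-fold lower number from compound 1 to compound 2 (0.61 log units; beyond the scatter), rests only on a difference in configuration as drawn, because of the fact that compounds 1 and 2 differ only in the configuration as drawn; the atoms and bonds are the same.

Compound 3 `CC(=O)OC[C@H]1O[C@@H](SC(=S)C2=C(Nc3ccc(Cl)cc3)CC(C)(C)CC2=O)[C@H](OC(C)=O)[C@@H](OC(C)=O)[C@@H]1OC(C)=O` is the next compound. Relative to compound 1 the change is hydrogen in place of chloro on an aromatic carbon: 2,4-dichlorophenyl becomes 4-chlorophenyl. Among the measured compounds shown here, no measured step involves a chloro group, so the stereochemical step gives no guidance on its size or direction. Without evidence of that kind, the expectation for compound 3 is a step within the usual scatter, a 1.0-fold higher number from compound 1 to compound 3 (0.01 log units; within the scatter), with the direction open. Compound 3 is therefore estimated at 16 ug/mL, within a range from 6 ug/mL to 45 ug/mL.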

Compound 3, half-maximal inhibitory concentration: 9.9 ug/mL
Estimate against measurement, compound 3: 1.6-fold (0.21 log units) above, and the stated range covers the measured number.
By their numbers in this assay, from the lowest: compound 2; then compounds 3 and 1 (each within the scatter of the next).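

In this assay, replacing the chloro group of compound 1 with hydrogen, which turns 2,4-dichlorophenyl into 4-chlorophenyl, gives a 1.6-fold lower number from compound 1 to compound 3 (0.20 log units; within the scatter). So at this place, ortho to a large group, the chloro group is not needed to keep the inhibition seen with compound 1, and this is the first sign that the aromatic part of the molecule can be changed without a step beyond the scatter. Nothing given here explains this result.

The compounds shown leave open whether another group at this place, such as a methoxy or an amine, would be accepted, and what the remaining chloro group contributes. They also leave open whether the same replacement would behave alike in the configuration of compound 2.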